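The source may hold more compounds than are shown below. What is called first, only, known or untested is meant among the compounds shown, and "the series" means these compounds.

Compound 1 `Oc1ccc(O)c(-c2cc(-c3ccc(Cl)cc3)nn2-c2ccccc2)c1` gives 32000 nM in a functional assay on cells (Cancer cell lines, Homo sapiens) for cytotoxicity, read by sulforhodamine B assay, with a stated time of 48 h; on this read-out higher numbers stand for weaker inhibition of growth and lower numbers for stronger inhibition of growth.
Compound 2 `CC(=O)NS(=O)(=O)c1ccc(-n2nc(-c3ccc(Cl)cc3)cc2-c2cc(O)ccc2O)cc1` gives 59800 nM in this assay.

Going by the values given here, compound 1 stands at the lower of the two numbers so far, with compound 2 nearest to it: the step of a 1.9-fold higher number from compound 1 to compound 2 (0.27 log units; within the scatter) came from putting acetylsulfamoyl in place of hydrogen on an aromatic carbon, and it lies within the scatter. Compound 3 `O=C1C=CC(=O)C(c2cc(-c3ccc(Cl)cc3)nn2-c2ccccc2)=C1` has not yet been measured. It differs from compound 1 in one place: a group of 8 heavy atoms (6 carbon, 2 oxygen; one six-membered non-aromatic ring of carbon only) in place of a group of 8 heavy atoms (6 carbon, 2 oxygen; one six-membered aromatic ring of carbon only), on an aromatic carbon. The group that leaves is the 2,5-dihydroxyphenyl with its two hydrogen-bond donors; the group that enters has no common name, keeps two hydrogen-bond acceptors and has no donors, and its six-membered ring is non-aromatic, with four double bonds outside aromatic rings. Among the compounds with values here, no measured step touches this position or this kind of exchange; the only step known, from compound 1 to compound 2, changes a different ring and falls within the scatter. The expectation for compound 3 therefore rests on compound 1 alone, and a step of a 1.6-fold lower number from compound 1 to compound 3 (0.20 log units; within the scatter) is expected, with a wide range in either direction. Compound 3 is estimated at 20000 nM in this assay, between 5000 nM and 80000 nM.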

Compound 3, concentration for total growth inhibition: 53300 nM
The estimate for compound 3 lay 2.7-fold (0.43 log units) below the measured number; the measured number falls inside the stated range.
By their numbers in this assay, from the lowest: compounds 1, 3 and 2 (each within the scatter of the next).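

In this assay, going by these compounds alone, the exchange of the 2,5-dihydroxyphenyl for the non-aromatic six-membered ring without hydrogen-bond donors gave a 1.7-fold higher number from compound 1 to compound 3 (0.22 log units; within the scatter) and so provides the first reading at this position. At this position on the core of compound 1, then, neither the donors nor the aromatic character of the ring proved necessary for a number within the scatter of that of compound 1, although this rests on a single exchange and a single read-out. Nothing available bears on why the two groups read alike here.

The compounds shown leave open whether any group at this position would move the number beyond the scatter, for instance an unsubstituted phenyl, a 2,5-dimethoxyphenyl or a ring bearing an amine or a carboxylic acid. They also leave open whether the same exchange would read alike with the acetylsulfamoyl on the phenyl group, or with something other than the 4-chlorophenyl group on the shared core.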